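Rearranging the Cyanoguanidine Chain of Compound 3

The compounds below may be only part of what the source reports. "The series", "measured", "known", "first", "only" and "open" are said of these compounds alone.

Among the compounds with values here, compound 3 `N#CNC(=N)NCCCCn1nc(-c2ccccc2)ccc1=O` is the one compound here that gives an actual number in a functional assay on the whole organism (stomach) with Rattus norvegicus as the target; a higher number here means that more compound is needed for the effect, a lower number that less compound is needed: compound 3 gives 77.2 mg/kg. Compound 1 `CCC/N=C(/NC#N)NCCCCn1nc(-c2ccccc2)ccc1=O` is reported in this assay only as a limit, > 100 mg/kg. Compound 2 `C/N=C(\S)NCCCCn1nc(C)ccc1=O` likewise reaches only a limit in this assay, > 100 mg/kg. Within the data shown here, compound 3 therefore stands alone as the single measured value, set against (the limit of > 100 mg/kg in this assay, at which 2 of the 3 values shown sit).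

Among the measured compounds shown here, only one measured step is available: an at least 1.2-fold lower number from compound 1 to compound 3 (0.11 log units; that floor lies within the scatter). Its floor lies within the scatter, so it shows at best a small change when the larger group on the amine nitrogen gives way to the smaller one.

Compound 4 `C/N=C(/NC#N)NCCCn1nc(-c2ccccc2)ccc1=O` is built from the same atoms as compound 3 but joined differently: a group of 7 heavy atoms (3 carbon, 4 nitrogen; no ring) in place of a group of 7 heavy atoms (3 carbon, 4 nitrogen; no ring), on a saturated chain carbon, three bonds along the chain from an aromatic nitrogen. For the measured compounds named here, no measured step reports a rearrangement of this kind, and the one step that exists is small. The expectation for compound 4 in this assay is thus no change beyond the scatter, estimated as a 1.0-fold higher number from compound 3 to compound 4 (0.02 log units; within the scatter). Because compound 1 and compound 2 reach only the limit described in the limit of > 100 mg/kg in this assay, at which 2 of the 3 values shown sit, there is a real chance that compound 4 also returns only a limit rather than a number. Compound 4 is expected to give about 80 mg/kg, with a range from 30 mg/kg to 250 mg/kg.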

Compound 4, dose for half-maximal effect: > 100 mg/kg
Compound 4 was reported as a limit (the forecaster's own chance of this, stated with the estimate: 40%); at least 1.2-fold (0.09 log units) between middle value and limit.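

Rearranging the atoms at this place, on a saturated chain carbon, three bonds along the chain from an aromatic nitrogen, gives an at least 1.2-fold higher number from compound 3 to compound 4 (0.11 log units; that floor lies within the scatter) in this assay. The result for compound 4 is a limit and not a number, so only the floor of the step can be read, and the true gap could be small or much larger. This is the first sign that the same atoms, joined differently, do not lift compound 4 out of the group without a number, and compound 3 remains the only compound with a measured value, a picture that now looks more lopsided: the limit of > 100 mg/kg in this assay, at which 3 of the 4 values shown sit.

The rearrangement moves atoms between the chain and the end group in a single change, so the compounds shown cannot separate the contribution of the chain from that of the end group. From the compounds shown here alone, whether any other arrangement gives a measurable number stays open, for example a longer chain carrying the unchanged cyanoguanidine of compound 3, or an amine or a carboxylic acid in place of that cyanoguanidine.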